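The source may hold more compounds than are shown below. What is called first, only, known or untested is meant among the compounds shown, and "the series" means these compounds.

In an in vitro functional assay on HEK293-A cells for positive allosteric modulation of metabotropic glutamate receptor 5 (Homo sapiens), read by FLIPR and calcium flux (a lower number here means that less compound is needed, a higher number that more compound is needed for the effect), compound 3 `Cc1ccc(N2CC(c3nc(-c4cccc(F)c4)no3)CC2=O)cc1` gives 1200 nM, the lowest of the two numbers in hand. Going by the values given here, its nearest neighbour is compound 1 `Cc1ccc(N2CC(c3nc(-c4cccc(C(F)(F)F)c4)no3)CC2=O)cc1`, which gives 3400 nM; the step of a 2.8-fold lower number from compound 1 to compound 3 (0.45 log units; beyond the scatter) is the only measured step that bears on what follows. Compound 2 `COc1cccc(N2CC(c3nc(-c4cccc(Cl)c4)no3)CC2=O)c1` is known only as a limit of this assay, > 10000 nM (the limit of > 10000 nM in this assay, at which 1 of the 3 values shown sits). Compound 4 `Cc1ccc(N2CC(c3nc(-c4cccc(Cl)c4)no3)CC2=O)cc1` differs from compound 3 by chloro in place of fluoro on an aromatic carbon. Among the compounds with values here, no measured step covers chloro in place of fluoro, so the expectation rests on the fluoro-to-trifluoromethyl step and the chloro-bearing limit of compound 2, which together suggest a modest rise. Compound 4 is therefore expected at 2000 nM, between 800 nM and 5000 nM, a step of a 1.7-fold higher number from compound 3 to compound 4 (0.22 log units; within the scatter).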

Compound 4, half-maximal effective concentration: 630 nM
Compound 4: the middle estimate sits 3.2-fold (0.50 log units) above what was measured, outside the stated range (below it).
By their numbers in this assay, from the lowest: compounds 4 and 3 (each within the scatter of the next); then compound 1. At a limit, above all of these: compound 2.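

On this aromatic carbon, chloro and fluoro are not told apart in this assay: the result is a 1.9-fold lower number from compound 3 to compound 4 (0.28 log units; within the scatter). Chloro also gives a 5.4-fold lower number from compound 1 to compound 4 (0.73 log units; beyond the scatter), so both halogens now stand clear of trifluoromethyl. With 3-chlorophenyl held fixed, the change on the amide-type nitrogen gives an at least 15-fold lower number from compound 2 to compound 4 (1.20 log units; beyond the scatter), the only large step shown, and it rests on a limit: the limit of > 10000 nM in this assay, at which 1 of the 4 values shown sits.

The compounds shown leave open how a nitrile or an amine on this aromatic carbon would read. They also leave open whether the methyl or the methoxy group, or the place each holds, carries that large step.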